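A Longer Chain on Compound 3

The compounds below may be only part of what the source reports. "The series", "measured", "known", "first", "only" and "open" are said of these compounds alone.

Measured in an ADME assay on HEp-2 cells (Homo sapiens) for cytotoxicity, read by MTT assay, with a stated time of 24 h; a higher number here means that more compound is tolerated, a lower number that less compound is tolerated
compound 1 (`CCCOC(=O)CCc1ccc(O)c(O)c1`) gives > 200 ug/mL as a limit of the assay
compound 2 (`CCCCOC(=O)CCc1ccc(O)c(O)c1`) gives 200 ug/mL
compound 3 (`CCC(=O)OCCc1ccc(O)c(O)c1`) gives 40 ug/mL

Compound 3 holds the lowest number of the set at 40 ug/mL, and compound 2 stands at 200 ug/mL. That gap lies beyond the scatter, and so less of compound 3 is tolerated. The reading for compound 1 is a limit and gives no number to compare.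

Compound 4 (`CCCC(=O)OCCc1ccc(O)c(O)c1`) differs from compound 3 by a single change (methyl in place of hydrogen on a saturated chain carbon, two bonds along the chain from a carbonyl carbon) with methyl in place of hydrogen on a saturated chain carbon, two bonds along the chain from a carbonyl carbon, so that propanoyl becomes propylcarbonyl.

Among the measured compounds shown here, the one measured step of a similar kind is a number no higher from compound 1 to compound 2 (the limit leaves the size open) where a methyl also replaces hydrogen on a saturated chain carbon, though three bonds along the chain from an oxygen. That step starts from the limit of > 200 ug/mL in this assay, at which 1 of the 3 values shown sits, and so shows no size, only a direction that does not rise. Nothing measured supports a large move, and a slight fall or none is expected. In this assay the expected step is a 1.1-fold lower number from compound 3 to compound 4 (0.06 log units; within the scatter) and it stays within the scatter. Compound 4 is estimated at 35 ug/mL with an expected range from 15 ug/mL to 90 ug/mL when it is measured.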

Compound 4, half-maximal cytotoxic concentration: 100 ug/mL
Compound 4: the middle estimate sits 2.9-fold (0.46 log units) below what was measured; the measured number lies above the stated range.
By their numbers in this assay, from the lowest: compound 3; then compounds 4 and 2 (each within the scatter of the next).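

In this assay, methyl in place of hydrogen on a saturated chain carbon, two bonds along the chain from a carbonyl carbon, gives a 2.5-fold higher number from compound 3 to compound 4 (0.40 log units; beyond the scatter). This is the first step of this kind in the set with a readable size, and it shows that at this position the change, propanoyl to propylcarbonyl, raises the amount of compound tolerated rather than leaving it flat or lowering it. The earlier step of this kind gave only a direction, so the two cannot be set side by side as sizes: the same change on two cores in this assay, a number no higher (the limit leaves the size open) from compound 1 to compound 2 and a 2.5-fold higher number (0.40 log units; beyond the scatter) from compound 3 to compound 4; the limit leaves it open whether they differ

Going by these compounds, the shared core of compound 3 and compound 4 thus offers a single step, which sets no trend, and it remains open whether a longer chain at this place would carry the number further up, level off or bring it back down. It is equally open how a branched chain, an amine or a carboxylic acid on this same chain carbon would read in this assay, as the compounds shown hold only unbranched chains without such groups.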